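A few compounds are considered here, and "the series" means these few. Any claim that something is new, unique, unknown or untested is made for them only; others in the source may bear on it.

For the measured compounds named here, in a functional assay on MGC-803 cells (Homo sapiens) for inhibition, read by MTT assay, with a stated time of 72 h (on this read-out lower numbers stand for stronger inhibition and higher numbers for weaker inhibition), compound 3 `N#Cc1c(Nc2ccccc2Cl)nc(SCc2cn(Cc3ccccc3Cl)nn2)nc1-c1ccccc1` gives 4640 nM, the only number among the three results in hand. Compound 1 `C#CCSc1nc(Nc2ccc(Cl)cc2)c(C#N)c(-c2ccccc2)n1` reaches only a limit of this assay, reported as > 128000 nM. Compound 2 `C#CCSc1nc(Nc2cccc(Cl)c2)c(C#N)c(-c2ccccc2)n1` likewise stops at a limit, reported as > 128000 nM. The step that the two limits leave unreadable from compound 1 to compound 2 is therefore unreadable, and what the two compounds show is summed up by the limit of > 128000 nM in this assay, at which 2 of the 3 values shown sit. Compound 4 `COc1ccccc1Nc1nc(SCc2cn(Cc3ccccc3Cl)nn2)nc(-c2ccccc2)c1C#N` has not yet been measured in this assay; it differs from compound 3 by methoxy in place of chloro on an aromatic carbon. Going by the values given here, none of the measured steps bears on this change: the one step available is unreadable, and no other pair in hand differs in this way. With nothing to point in either direction, the step of a 1.0-fold lower number from compound 3 to compound 4 (0.00 log units; within the scatter) is expected to stay within the usual scatter of repeated measurements in this assay. For compound 4 the estimate in this assay is 4600 nM, with a range from 1500 nM to 15000 nM.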

Compound 4, half-maximal inhibitory concentration: 5800 nM
The estimate for compound 4 lay 1.3-fold (0.10 log units) below the measured number; the range from low to high includes it.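

In this assay the change reads as a 1.3-fold higher number from compound 3 to compound 4 (0.10 log units; within the scatter), the first step among these compounds with a readable size, since the step between compound 1 and compound 2 cannot be read. At this place, on an aromatic carbon ortho to a large group, 2-methoxyphenyl thus takes the place of 2-chlorophenyl, two heavy atoms and a hydrogen-bond acceptor replacing one chlorine, without the read-out separating the two compounds. Nothing measured here gives a reason for this result.

From the compounds shown here alone, whether an amine, a hydroxyl or a longer chain such as ethoxy at this same place would also leave the number within the scatter stays open. Also open, going by these compounds, is whether methoxy would match chloro at another carbon of this ring.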